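Fluoro in Place of Bromo on the Phenyl Ring

A few compounds are considered here, and "the series" means these few. Any claim that something is new, unique, unknown or untested is made for them only; others in the source may bear on it.

Of the compounds shown here, two have been tested in an assay for inhibition of histone-lysine N-methyltransferase, H3 lysine-79 specific (Homo sapiens), with stated times of 15 min and 120 min, tested at 50 uM; a lower number here means less inhibition, a higher number more inhibition at the concentration tested (going by the name of the read-out). Compound 1 `Cc1ccccc1Cc1nnc2sc(-c3cccc(F)c3)nn12` gives 27%. Compound 2 `Brc1cccc(-c2nn3c(Cn4cnc5ccccc54)nnc3s2)c1` gives 62%, the higher of the two numbers, and its gap to compound 1 lies beyond the usual scatter. Compound 3 `Fc1cccc(-c2nn3c(Cn4cnc5ccccc54)nnc3s2)c1` differs from compound 2 in one way: fluoro in place of bromo on an aromatic carbon. Going by the values given here, no measured pair shows this change by itself, so its effect is uncertain. Compound 1 also carries fluoro on its phenyl ring and gives only 27%, so a drop is expected. The step expected is a number 20 percentage points lower from compound 2 to compound 3 (beyond the scatter). For compound 3 the estimate is 42%, within 22% to 62%.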

Compound 3, a percentage reported as inhibition, at one concentration (the size of the read-out at that concentration, not a potency): 57%
Estimate against measurement, compound 3: 15 percentage points below, and the stated range covers the measured number.
By their numbers in this assay, from the lowest: compound 1; then compounds 3 and 2 (each within the scatter of the next).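

In this assay fluoro in place of bromo gives a number 5 percentage points lower from compound 2 to compound 3 (within the scatter) so the two halogens cannot be told apart at this position. With the same 3-fluorophenyl group, compound 1 gives 27% and compound 3 gives 57% so fluoro does not by itself go with the low number; these two compounds differ in another place. No evidence is available to explain why this swap changes so little. Going by these compounds, whether an amine or a carboxylic acid in this position would keep the inhibition remains open.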